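Second methoxy on the shared core: anticipated outcome

A few compounds are considered here, and "the series" means these few. Any claim that something is new, unique, unknown or untested is made for them only; others in the source may bear on it.

Measured in a functional assay on U-251 cells (Homo sapiens) for inhibition, read by sulforhodamine B assay, with a stated time of 48 h; on this read-out higher numbers stand for weaker inhibition of growth and lower numbers for stronger inhibition of growth:
- compound 1, `O=C1C=COC(/C=C/c2ccccc2)C1`: 122 uM
- compound 2, `COc1ccc(/C=C/C2CC(=O)C=CO2)cc1`: 152 uM

Compound 2 gives the higher of the two numbers, but the step of a 1.2-fold higher number from compound 1 to compound 2 (0.10 log units; within the scatter) is within the scatter, so the two compounds cannot be ranked. Compound 3, `COc1ccc(/C=C/C2CC(=O)C=CO2)cc1OC`, differs from compound 2 by methoxy in place of hydrogen on an aromatic carbon. For the measured compounds named here, the only step that bears on this change is a 1.2-fold higher number from compound 1 to compound 2 (0.10 log units; within the scatter), which was too small to count. For compound 3 no step beyond the scatter is therefore expected in this assay, in either direction. Compound 3 is expected at about 150 uM, within 70 uM to 320 uM, an expected step of a 1.0-fold lower number from compound 2 to compound 3 (0.01 log units; within the scatter).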

Compound 3, concentration for growth inhibition (reported as GI): 86.9 uM
Estimate against measurement, compound 3: 1.7-fold (0.24 log units) above, and the stated range covers the measured number.
By their numbers in this assay, from the lowest: compounds 3, 1 and 2 (each within the scatter of the next).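

Methoxy in place of hydrogen, ortho to a methoxy group and meta to a group of 9 heavy atoms, gives a 1.7-fold lower number from compound 2 to compound 3 (0.24 log units; within the scatter) in this assay and so adds no readable change. Across the series so far, neither methoxy step lies beyond the scatter, including a 1.2-fold higher number from compound 1 to compound 2 (0.10 log units; within the scatter) on the first methoxy. No measurement here speaks to the reason for this result.

On these data alone, whether an amine, a carboxylic acid or a longer chain such as ethoxy at this place would give a step beyond the scatter remains open. The methoxy steps alone do not show whether any substituent on this ring can move growth inhibition.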